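The source may hold more compounds than are shown below. What is called first, only, known or untested is meant among the compounds shown, and "the series" means these compounds.

In a functional assay on MIA PaCa-2 cells (Homo sapiens) for inhibition, read by MTT assay, with a stated time of 3 days (a lower number here means a stronger inhibitor, a higher number a weaker inhibitor), three compounds have numbers: compound 1, `CCN(CC)S(=O)(=O)c1ccc(S(=O)(=O)N2CCC[C@@H](C(=O)N[C@@H]3CCN(C(=O)OC(C)(C)C)C3)C2)cc1`, gives 500 nM, and compound 3, `CCN(CC)S(=O)(=O)c1ccc(S(=O)(=O)N2CCC[C@@H](C(=O)NC3COC3)C2)cc1`, gives 900 nM. Compound 2, `CCN1CC(NC(=O)[C@@H]2CCCN(S(=O)(=O)c3ccc(S(=O)(=O)N(CC)CC)cc3)C2)C1`, reaches only the assay limit, > 10000 nM.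

Compound 3 holds the higher of the two numbers, yet its gap to compound 1 is within the scatter (a 1.8-fold higher number from compound 1 to compound 3 (0.26 log units; within the scatter)). Compound 4, `CCN(CC)S(=O)(=O)c1ccc(S(=O)(=O)N2CCC[C@@H](C(=O)N3CCN(c4nc(C)no4)CC3)C2)cc1`, differs from compound 3 by 4-(3-methyl-1,2,4-oxadiazol-5-yl)piperazin-1-yl in place of (oxetan-3-yl)amino on a carbonyl carbon. All measured steps alter this same amide substituent: a 1.8-fold higher number from compound 1 to compound 3 (0.26 log units; within the scatter) was small, whereas an at least 20-fold higher number from compound 1 to compound 2 (1.30 log units; beyond the scatter) and an at least 11-fold lower number from compound 2 to compound 3 (1.04 log units; beyond the scatter) were large, so this position can move the number strongly. Among the compounds with values here, compound 4 removes the amide hydrogen and brings in a much larger group, which no measured step covers, so a weakening beyond the scatter is expected, with wide uncertainty. The expected step is a 2.2-fold higher number from compound 3 to compound 4 (0.35 log units; beyond the scatter). For compound 4 the estimate is 2000 nM, between 400 nM and 10000 nM.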

Compound 4, half-maximal inhibitory concentration: 200 nM
Estimate against measurement, compound 4: 10-fold (1.00 log units) above, outside the stated range (below it).
By their numbers in this assay, from the lowest: compound 4; then compounds 1 and 3 (each within the scatter of the next). At a limit, above all of these: compound 2.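

Putting 4-(3-methyl-1,2,4-oxadiazol-5-yl)piperazin-1-yl in place of (oxetan-3-yl)amino on the carbonyl carbon gives a 4.5-fold lower number from compound 3 to compound 4 (0.65 log units; beyond the scatter), so this position needs neither the amide hydrogen nor a small group. The distance to the inactive end of the series is also wide, with an at least 50-fold lower number from compound 2 to compound 4 (1.69 log units; beyond the scatter). That step is only a bound, since compound 2 sits at a limit of the assay: the limit of > 10000 nM in this assay, at which 1 of the 4 values shown sits.

The compounds shown do not separate the share of the piperazine ring from that of the oxadiazole ring in this step. A piperazin-1-yl carrying an acetyl group instead of the oxadiazole would be the open comparison.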